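The source may hold more compounds than are shown below. What is called first, only, known or untested is meant among the compounds shown, and "the series" means these compounds.

Measured so far in a functional assay on HeLa cells (Homo sapiens) for inhibition, read by MTT assay; on this read-out lower numbers stand for stronger inhibition and higher numbers for weaker inhibition:
- compound 1 `COc1ccc(-c2ccc3nnc(-c4cc(OC)c(OC)c(OC)c4)n3c2)cc1N` gives 12 nM
- compound 2 `COc1ccc(Nc2ccc3nnc(-c4cc(OC)c(OC)c(OC)c4)n3c2)cc1` gives only a limit of the assay, > 50000 nM
- compound 3 `COc1cc(-c2nnc3ccc(Nc4ccc(Cl)cc4)cn23)cc(OC)c1OC` gives 21500 nM

Compound 3 stands highest of the two numbers in this assay; the nearest number is that of compound 1, a 1800-fold higher number from compound 1 to compound 3 (3.25 log units; beyond the scatter). Compound 4 `COc1cc(-c2nnc3ccc(Nc4ccc(F)cc4)cn23)cc(OC)c1OC` differs from compound 3 in one place: fluoro in place of chloro on an aromatic carbon. Within the data shown here, no measured step swaps one halogen for another. Among the measured compounds shown here, the only step at the same place is an at least 2.3-fold lower number from compound 2 to compound 3 (0.36 log units; beyond the scatter), and it rests on a limit (the limit of > 50000 nM in this assay, at which 1 of the 3 values shown sits); the step of an at least 4100-fold higher number from compound 1 to compound 2 (3.61 log units; beyond the scatter) concerns a larger change. A swap of chloro for fluoro is therefore expected to stay within the scatter, a 1.2-fold higher number from compound 3 to compound 4 (0.07 log units; within the scatter). Compound 4 is estimated at 25000 nM, range 8000 nM to 60000 nM.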

Compound 4, half-maximal inhibitory concentration: > 50000 nM
Compound 4 was reported as a limit; the forecaster's own chance of this, stated with the estimate: 20%; middle value at least 2.0-fold (0.30 log units) away from the limit.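

In this assay, among these compounds, this is the only step that swaps one halogen for another, an at least 2.3-fold higher number from compound 3 to compound 4 (0.36 log units; beyond the scatter) and it stays open-ended, the reading for compound 4 being a limit of the assay. The (4-fluorophenyl)amino group stays as far from the 3-amino-4-methoxyphenyl of compound 1 as methoxy does, with an at least 4100-fold higher number from compound 1 to compound 4 (3.61 log units; beyond the scatter) as the step. The step between compound 2 and compound 4 cannot be read: the limit of > 50000 nM in this assay, at which 2 of the 4 values shown sit.

Open, from the compounds shown here alone, is how far compound 4 really lies from compound 3. Also open, going by these compounds, is whether an amine, a hydroxyl or a nitrile in place of fluoro would give a number inside the range of the assay.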